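A carboxylic acid moved around a phenoxymethyl ring

This account rests on a few compounds, and the source may have more. Where it says the series, first, only, none or still open, it means among the compounds named here.

Measured compounds:
compound 1 `CN(Cc1cccc(C(=O)O)c1)c1ccc(OCc2c(-c3c(Cl)cccc3Cl)noc2C2CC2)nc1C(F)(F)F` gives 3 nM
compound 2 `O=C(O)c1ccccc1OCc1ccc(OCc2c(-c3c(Cl)cccc3Cl)noc2C2CC2)nc1C(F)(F)F` gives 434 nM

Compound 2 holds the highest of the two numbers in an assay on isolated protein for agonist activity at Bile acid receptor (Homo sapiens), read by FRET (a lower number here means that less compound is needed, a higher number that more compound is needed for the effect), and its nearest neighbour is compound 1, which is separated from it by a 140-fold higher number from compound 1 to compound 2 (2.16 log units; beyond the scatter). Compound 3 `O=C(O)c1ccc(OCc2ccc(OCc3c(-c4c(Cl)cccc4Cl)noc3C3CC3)nc2C(F)(F)F)cc1` keeps the atoms of compound 2 and joins them differently: 4-carboxyphenyl in place of 2-carboxyphenyl on an oxygen on a saturated carbon. Within the data shown here, no measured step covers this change. Among the measured compounds shown here, the only measured step, the one from compound 1 to compound 2, replaces the whole linker together with the ring, so it shows that this region carries a large share of the activity but does not separate the place of the acid from the linker. Compound 3 is therefore expected to sit in the same range, with a modest step that is expected to be a 2.2-fold lower number from compound 2 to compound 3 (0.34 log units; beyond the scatter). The estimate for compound 3 in this assay is 200 nM, with a range from 30 nM to 1500 nM.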

Compound 3, half-maximal effective concentration: 76 nM
Estimate against measurement, compound 3: 2.6-fold (0.42 log units) above, and the stated range covers the measured number.
By their numbers in this assay, from the lowest: compound 1; then compound 3; then compound 2.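

In this assay, changing only where the acid sits on the ring, with 4-carboxyphenyl in place of 2-carboxyphenyl on an oxygen on a saturated carbon, gives (a 5.7-fold lower number from compound 2 to compound 3 (0.76 log units; beyond the scatter)), so the place of the acid matters with the linker held constant, which the earlier step could not show. Even with the acid in this place, the (4-carboxyphenoxy)methyl group does not reach the (3-carboxybenzyl)(methyl)amino group of compound 1, and the step remains large (a 25-fold higher number from compound 1 to compound 3 (1.40 log units; beyond the scatter)). No measurement is available to explain either step.

The compounds shown do not divide the remaining gap between the linker and the place of the acid, as compound 1 and compound 3 differ in both. Also open, from the compounds shown here alone, is whether a tetrazole or an amide could stand in for the carboxylic acid on this ring.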